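Aryl replacement at the fused-ring substituent in the series

The source may report more compounds than this note shows. Statements on the series, on what has been measured and on what is new or still open speak of the compounds shown alone.

In a functional assay on DU-145 cells (Homo sapiens) for antiproliferative activity, read by WST assay, with a stated time of 7 days, tested at 1 uM (on this read-out higher numbers stand for a stronger effect at the one concentration tested and lower numbers for a weaker effect), compound 3 `Cc1[nH]n(-c2nc3cc(C(F)(F)F)ccc3[nH]2)c(=O)c1Cc1ccccc1` gives 90%, the highest of the three numbers; compound 1 `Cc1[nH]n(-c2nc3cc(Cl)ccc3[nH]2)c(=O)c1Cc1ccccc1` with 84% sits within the scatter of it, while compound 2 `Cc1ccc2[nH]c(-n3[nH]c(C)c(Cc4ccccc4)c3=O)nc2c1` with 34% lies far below. The steps of a number 6 percentage points higher from compound 1 to compound 3 (within the scatter) and a number 56 percentage points higher from compound 2 to compound 3 (beyond the scatter) show that what sits on this aromatic carbon can move the read-out strongly or hardly at all. Compound 4 `Cc1[nH]n(-c2nc3cc(-c4ccc(Cl)cc4)ccc3[nH]2)c(=O)c1Cc1ccccc1` carries 4-chlorophenyl in place of trifluoromethyl on an aromatic carbon. Among the compounds with values here, no measured step puts a 4-chlorophenyl at this place, so the expectation rests only on those two steps and is uncertain; a step within the scatter or a moderate loss seems most likely. Compound 4 is expected to give 72%, between 40% and 95%, an estimated step of a number 18 percentage points lower from compound 3 to compound 4 (beyond the scatter).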

Compound 4, a percentage reported as inhibition, at one concentration (the size of the read-out at that concentration, not a potency): 91%
Compound 4: middle estimate off by 19 percentage points, on the low side, within the range that was stated.
By their numbers in this assay, from the lowest: compound 2; then compounds 1, 3 and 4 (each within the scatter of the next).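

A group carrying its own aromatic ring is accommodated at this aromatic carbon: a number 1 percentage points higher from compound 3 to compound 4 (within the scatter) and a number 7 percentage points higher from compound 1 to compound 4 (within the scatter) leave 4-chlorophenyl level with trifluoromethyl and chloro. Methyl alone stands apart among the four groups, as a number 57 percentage points higher from compound 2 to compound 4 (beyond the scatter) shows, so added size at this place does not by itself lower the read-out. No available evidence accounts for the gap to methyl.

From the compounds shown here alone, whether an amine or a carboxylic acid at this carbon would hold the read-out remains open. So does the contribution of the chlorine, which plain phenyl would address.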